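Plasma protein binding of pyrimidinyl-pyrrolidine ureas: methoxy analogue

The source may hold more compounds than are shown below. What is called first, only, known or untested is meant among the compounds shown, and "the series" means these compounds.

Measured so far:
compound 1 `CNc1nccc(N2CC[C@H](NC(=O)Nc3ccc(OC(F)(F)F)cc3)C2)n1` — 97.7%
compound 2 `CNc1nccc(N2CC[C@H](NC(=O)Nc3ccc(CN4CCN(C)CC4)c(C(F)(F)F)c3)C2)n1` — 87.6%
compound 3 `O=C(Nc1ccc(Cl)c(C(F)(F)F)c1)N[C@H]1CCN(c2ccnc(NC3CC3)n2)C1` — > 99.9%

The read-out is an ADME assay on a cell-free system (plasma, Homo sapiens) for protein binding. In this assay compound 1 gives 97.7%, the lowest unbound fraction among the two numerical values; compound 2 gives 87.6%, a higher unbound fraction, and the gap between the two is beyond the scatter. For compound 3 the result is a limit, > 99.9%; one of the three values sits at the limit of > 99.9% in this assay, at which 1 of the 3 values shown sits.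

Compound 4 `CNc1nccc(N2CC[C@H](NC(=O)Nc3ccc(OC)cc3)C2)n1` is not yet measured. It differs from compound 1 by methyl in place of trifluoromethyl on an oxygen on an aromatic ring, the same change read one bond further out being trifluoromethoxy to methoxy. Going by the values given here, no measured pair with a single difference is available to size such a step. The expected step a 2.2-fold higher unbound fraction from compound 1 to compound 4 (0.34 log units; beyond the scatter) is towards a lower bound fraction and is estimated to lie beyond the scatter. Compound 4 is estimated at 95%, with a range from 90% to 98%.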

Compound 4, plasma protein binding in the Homo sapiens assay: 80%
The estimate for compound 4 lay 4.0-fold (0.60 log units) (unbound fraction) below the measured number; the whole stated range lies above it.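

In the Homo sapiens assay the change from trifluoromethyl to methyl on an oxygen on an aromatic ring gives an 8.7-fold higher unbound fraction from compound 1 to compound 4 (0.94 log units; beyond the scatter) and is the only single-place step shown, so this position alone can move plasma protein binding by more than the scatter. In a physicochemical assay for solubility, measured as kinetic solubility (on this read-out lower numbers stand for lower solubility and higher numbers for higher solubility), compound 1 gives 70400 nM and compound 4 gives 92600 nM, and the step of a 1.3-fold higher number from compound 1 to compound 4 (0.12 log units; within the scatter) lies within the scatter. This pair is therefore separated in the Homo sapiens assay and not in the physicochemical assay.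

The data shown give no cause for the step in binding. Also open, on these data alone, is how binding would respond with an amine, a carboxylic acid or a longer chain on this oxygen, and whether the same change gives a similar step on the other compounds.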